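Adding a methyl group to two related chalcone and pyrazoline cores

The compounds below may be only part of what the source reports. "The series", "measured", "known", "first", "only" and "open" are said of these compounds alone.

Compound 1: `Cc1nc(C)c(-c2nn(-c3ccc(F)cc3)cc2/C=C/C(=O)c2cc(Cl)c(C)cc2O)s1`, 34.9 ug/mL
Compound 2: `Cc1nc(C)c(-c2nn(-c3ccc(F)cc3)cc2/C=C/C(=O)c2c(O)cc(C)c(Cl)c2C)s1`, 59.3 ug/mL
Compound 3: `Cc1nc(C)c(-c2nn(-c3ccc(F)cc3)cc2C2CC(c3cc(Cl)c(C)cc3O)=NN2)s1`, > 250 ug/mL

In an ADME assay on HeLa cells (Homo sapiens) for inhibition, read by MTT assay (a lower number here means a stronger inhibitor of growth, a higher number a weaker inhibitor of growth), compound 1 gives 34.9 ug/mL and compound 2 gives 59.3 ug/mL. The change between them is methyl in place of hydrogen on an aromatic carbon, and the step it made is a 1.7-fold higher number from compound 1 to compound 2 (0.23 log units; within the scatter). Compound 3 carries a different core; how its core differs from that of compound 1 is not broken down here. For compound 3 this assay reports only a limit, > 250 ug/mL. That limit is the point described by the limit of > 250 ug/mL in this assay, at which 1 of the 3 values shown sits.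

Compound 4, `Cc1nc(C)c(-c2nn(-c3ccc(F)cc3)cc2C2CC(c3c(O)cc(C)c(Cl)c3C)=NN2)s1`, is not yet measured. It differs from compound 3 by methyl in place of hydrogen on an aromatic carbon, the same change as that from compound 1 to compound 2. Since the earlier step sat within the scatter, the step from compound 3 to compound 4 is expected to be similarly small, a step that the limit leaves unreadable from compound 3 to compound 4. Because compound 3 already stands at the limit > 250 ug/mL, compound 4 is expected to give around 300 ug/mL, most likely again as a limit rather than a number, somewhere between 150 ug/mL and 600 ug/mL.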

Compound 4, concentration for 50% growth inhibition: 25.2 ug/mL
Compound 4: middle estimate off by 12-fold (1.08 log units), on the high side, outside the stated range (below it).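

In this assay, methyl in place of hydrogen on an aromatic carbon gives an at least 9.9-fold lower number from compound 3 to compound 4 (0.99 log units; beyond the scatter), a clear move towards stronger growth inhibition on this core, unlike the small step seen on the core of compound 1. From the compounds shown here alone, the same change therefore does not carry over with the same size from one core to the other: the same change on two cores in this assay, a 1.7-fold higher number (0.23 log units; within the scatter) from compound 1 to compound 2 and an at least 9.9-fold lower number (0.99 log units; beyond the scatter) from compound 3 to compound 4, at least 16-fold (1.22 log units) apart, beyond the scatter of two such steps Compound 3 is reported only as a limit, > 250 ug/mL, so the full size of its step stays unknown, and two pairs of compounds cannot show why the two cores respond differently or how any further core would respond.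

The compounds shown carry only hydrogen or methyl at this aromatic carbon, so it remains open whether an ethyl group, a methoxy group or an amine there would follow either core's result. Going by these compounds, it also remains open whether the large step on the core of compound 3 would appear in any readout other than this assay.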